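The source may hold more compounds than are shown below. What is called first, only, known or untested is meant among the compounds shown, and "the series" means these compounds.

Working notes on the series. Compound 1 `CC(C)[C@H](NC(=O)CN(c1nc(Cl)nc2[nH]cnc12)C1CC1)C(=O)OCc1ccccc1` is measured in a functional assay on the whole organism (Tail, strain ICR) with Mus musculus as the target, in the tail flick test, with a stated time of 150 min, at a dose of 25 umol/kg by the oral route (a higher number here means a stronger effect of the compound at the dose given, a lower number a weaker effect), and gives 17.9%. Compound 2 `O=C(OCc1ccccc1)[C@@H]1CCCN1C(=O)CN(c1nc(Cl)nc2[nH]cnc12)C1CC1` gives 31.1% in this assay. Of these two numbers, compound 1 stands lowest, and the nearest, compound 2, lies higher by a margin beyond the scatter.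

Compound 3 `O=C(CN(c1nc(Cl)nc2[nH]cnc12)C1CC1)N[C@@H](CCC(=O)OCc1ccccc1)C(=O)OCc1ccccc1` remains to be measured in this assay. It differs from compound 1 in one place: 2-(benzyloxycarbonyl)ethyl in place of isopropyl on a saturated chain carbon bound to an amide-type nitrogen and a carbonyl carbon.

No step between measured compounds is shown for a change of this kind, so the comparison rests on the two values alone. With only the isopropyl side chain of compound 1 at 17.9% and a different ring-closed chain in compound 2 at 31.1% known, the expected step of a number 4.1 percentage points higher from compound 1 to compound 3 (within the scatter) is small and upward, possibly not beyond the scatter. For compound 3 the estimate in this assay is 22%, expected within 8% to 40%.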

Compound 3, a percentage reported as activity, at one dose (the size of the read-out at that dose, not a potency): 44.5%
For compound 3 the middle estimate is 22.5 percentage points below the measured one; the whole stated range lies below it.
By their numbers in this assay, from the lowest: compound 1; then compound 2; then compound 3.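

On a saturated chain carbon bound to an amide-type nitrogen and a carbonyl carbon, replacing isopropyl with 2-(benzyloxycarbonyl)ethyl gives a number 26.6 percentage points higher from compound 1 to compound 3 (beyond the scatter) in this assay. Going by these compounds alone, this is the first step read at this position, and it shows that the read-out can rise beyond the scatter with a larger side chain that carries a six-membered aromatic ring of carbon only and an ester. Nothing measured here bears on why the read-out rises.

As far as these compounds go, with this single step, the part of the entering group that goes with the rise stays open: a free carboxylic acid in place of the benzyl ester, or a plain n-butyl chain at the same place, would help to separate the ester from the chain. The read-out at one dose and one time also leaves potency open.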